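The source may report more compounds than this note shows. Statements on the series, on what has been measured and on what is new or still open speak of the compounds shown alone.

Three compounds have been measured in an assay on isolated protein for inhibition of cytohesin-2 (Homo sapiens), read by fluorescence; on this read-out higher numbers stand for weaker inhibition and lower numbers for stronger inhibition:

Compound 1, `Cc1cc(C)c(S(=O)(=O)Nc2ccc(O)cc2C)c(C)c1`, gives 980000 nM.
Compound 2, `Cc1cc(NS(=O)(=O)c2ccccc2)cc(C)c1O`, gives 5120000 nM.
Compound 3, `Cc1cc(O)cc(C)c1NS(=O)(=O)c1ccc([N+](=O)[O-])cc1`, gives 540000 nM.

Compound 3 has the lowest number of the three. Its gap to compound 1 falls within the usual scatter of repeated measurements, so those two cannot be told apart on this evidence; its gap to compound 2 lies beyond the scatter, so compound 3 is clearly a stronger inhibitor than compound 2 in this assay. The three compounds differ from one another in more than one place, so none of these gaps can be tied to a single change.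

Compound 4, `COc1ccc(S(=O)(=O)Nc2c(C)cc(O)cc2C)cc1`, has not yet been measured. It differs from compound 3 in one place: methoxy in place of nitro on an aromatic carbon. Among the compounds with values here, no measured pair isolates this exchange, so there is nothing to lean on but the values themselves, and the inhibition seen so far is weak throughout. The expectation is therefore a small step, if any, a 1.7-fold higher number from compound 3 to compound 4 (0.22 log units; within the scatter), most likely toward a somewhat higher number, though not certainly beyond the scatter. Compound 4 is thus expected to give about 900000 nM in this assay, with a plausible range from 250000 nM to 3000000 nM.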

Compound 4, inhibition constant: 1610000 nM
Estimate against measurement, compound 4: 1.8-fold (0.25 log units) below; measured number inside the range.
By their numbers in this assay, from the lowest: compounds 3, 1 and 4 (each within the scatter of the next, the first and the last beyond it); then compound 2.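

Swapping nitro for methoxy on an aromatic carbon para to a large group is the first single change here that can be read on its own, and in this assay it gives a 3.0-fold higher number from compound 3 to compound 4 (0.47 log units; beyond the scatter) with the rest of the molecule unchanged. Within the data shown here, the step is modest and the compounds are all weak inhibitors, but it shows that the group on this carbon can move the number beyond the usual scatter, something the earlier compounds could not show because they differ in more than one place. Nothing measured here tells why nitro and methoxy differ in this way.

Among these compounds, with only two groups compared at this carbon, it remains open whether nitro is a special case or one point in a broader trend, and whether any group could bring the number much lower. An amine, a carboxylic acid or a chlorine atom on the same carbon of compound 3 would test this, as would the same nitro-to-methoxy exchange on a different core.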